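This account rests on a few compounds, and the source may have more. Where it says the series, first, only, none or still open, it means among the compounds named here.

Of the compounds shown here, two have been measured in an assay on isolated protein for inhibition of Amine oxidase [flavin-containing] B (Homo sapiens), read by fluorescence and Amplex Red, with a stated time of 30 min, tested at 1 mM; a lower number here means a weaker effect, a higher number a stronger effect of the compound at the concentration tested. Compound 2 `CCCNc1nnc(SCC(=O)N(Cc2cccc([N+](=O)[O-])c2)c2ccc(F)cc2)s1` gives 42.7%; compound 1 `CCCCNc1nnc(SCC(=O)N(Cc2cccc([N+](=O)[O-])c2)c2ccc(F)cc2)s1` gives 40.6%, within the scatter of compound 2. The step of a number 2.1 percentage points higher from compound 1 to compound 2 (within the scatter) is the only measured one and bears on the chain in question. Compound 3 `CC(C)CNc1nnc(SCC(=O)N(Cc2cccc([N+](=O)[O-])c2)c2ccc(F)cc2)s1` differs from compound 2 by methyl in place of hydrogen on a saturated chain carbon bound to two saturated chain carbons. Among the compounds with values here, since the one measured step on this chain stayed within the scatter, the step from compound 2 to compound 3 is expected to be a number 0.7 percentage points lower from compound 2 to compound 3 (within the scatter), with no movement beyond the scatter in either direction. For compound 3 the expected value is 42%, with a range from 30% to 54%.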

Compound 3, a percentage reported as inhibition, at one concentration (the size of the read-out at that concentration, not a potency): 36%
Estimate against measurement, compound 3: 6 percentage points above; the range from low to high includes it.
By their numbers in this assay, from the lowest: compounds 3, 1 and 2 (each within the scatter of the next).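

Methyl in place of hydrogen on this saturated chain carbon puts a branch on the chain for the first time in the compounds shown, and in this assay it gives a number 6.7 percentage points lower from compound 2 to compound 3 (within the scatter). Isopropyl in place of propyl gives a number 4.6 percentage points lower from compound 1 to compound 3 (within the scatter), so branching, like the step in chain length, stays inside the scatter at this concentration. No measurement at hand offers an explanation for these numbers.

Still open, from the compounds shown here alone, is whether a cyclohexyl group, or a chain carrying a hydroxyl or an amine, would move the number beyond the scatter.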